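A few compounds are considered here, and "the series" means these few. Any claim that something is new, unique, unknown or untested is made for them only; others in the source may bear on it.

Measured compounds:
- compound 1 `COc1ccc(C(=O)/C=C/c2cc3ccccc3[nH]c2=O)cc1`; in a functional assay on HT-29 cells (Homo sapiens) for cytotoxicity, read by sulforhodamine B assay, with a stated time of 24 h (on this read-out lower numbers stand for stronger inhibition of growth and higher numbers for weaker inhibition of growth), compound 1 gives only a limit, > 100000 nM
- compound 2 `O=C(/C=C/c1cc2ccccc2[nH]c1=O)c1ccc(O)cc1`; in this assay compound 2 gives 12100 nM

For the measured compounds named here, compound 2 carries the only plain number so far in this assay; the other value of the pair is a limit, as recorded in the limit of > 100000 nM in this assay, at which 1 of the 2 values shown sits. Going by the values given here, the single measured step, an at least 8.2-fold lower number from compound 1 to compound 2 (0.91 log units; beyond the scatter), replaces methyl on the ring oxygen with hydrogen, so that the hydroxy-bearing compound 2 is the one with a number.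

Compound 3 `O=C(/C=C/c1cc2ccccc2[nH]c1=O)c1ccc(Cl)cc1` is the next point. It differs from compound 2 by chloro in place of hydroxy on an aromatic carbon: the hydroxy goes and a chloro takes its place, on an aromatic carbon of the six-membered ring of carbon only, para to a large group.

Among the compounds with values here, only the step of an at least 8.2-fold lower number from compound 1 to compound 2 (0.91 log units; beyond the scatter) bears on this position, and it shows that removing the hydroxy's hydrogen in favour of methyl costs at least a modest amount. Compound 3 has no hydroxy at all, so a step in the same unfavourable direction is expected, a 5.0-fold higher number from compound 2 to compound 3 (0.70 log units; beyond the scatter), with a real chance that only a limit is returned. The expected figure for compound 3 in this assay is 60000 nM, within 15000 nM to 200000 nM.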

Compound 3, concentration for total growth inhibition: 22500 nM
Estimate against measurement, compound 3: 2.7-fold (0.43 log units) above, within the range that was stated.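

In this assay, the change from 4-hydroxyphenyl to 4-chlorophenyl gives a 1.9-fold higher number from compound 2 to compound 3 (0.27 log units; within the scatter), so the earlier reading that a number at this position depends on the hydroxy does not hold: compound 3 has a chloro, with 0 hydrogen-bond donors, and still stays within the scatter of compound 2. For the compounds shown here, the chloro also separates from the methoxy, with an at least 4.4-fold lower number from compound 1 to compound 3 (0.64 log units; beyond the scatter), which leaves compound 1 as the one compound of the three that goes against a plain number at this aromatic carbon, so the methoxy, and not simply the absence of hydroxy, marks the difference in this small set. Both steps from compound 1 remain bounds and give no exact size because compound 1 gives only a limit: the limit of > 100000 nM in this assay, at which 1 of the 3 values shown sits.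

As far as these compounds go, whether an amine, a carboxylic acid or a fluoro on this aromatic carbon would sit with compound 2 and compound 3 or with compound 1 remains open, as does whether an ethoxy or a longer chain on the oxygen would behave like the methoxy. The shared core is also unchanged across all three compounds, so these notes say nothing about changes anywhere else on it.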